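The source may hold more compounds than are shown below. What is called first, only, known or untested is meant among the compounds shown, and "the series" means these compounds.

In a functional assay on KYSE-70 cells for antiproliferative activity against KYSE-70 cell line (Homo sapiens), read by MTT assay, with a stated time of 72 h (on this read-out higher numbers stand for weaker inhibition and lower numbers for stronger inhibition), compound 1 (`Cc1ccc(-c2ccc3c(C(=O)Nc4cccc(F)c4)cc(=O)[nH]c3c2)cc1`) gives > 20000 nM, which is a limit of the assay. Compound 2 (`Cc1cc(-c2ccc3c(C(=O)Nc4cccc(F)c4)cc(=O)[nH]c3c2)c(C)cc1F`) gives > 20000 nM, also a limit, so it stands without a readable number. Compound 3 (`C=Cc1ccc2c(C(=O)Nc3cccc(F)c3)cc(=O)[nH]c2c1`) differs from it as vinyl in place of 4-fluoro-2,5-dimethylphenyl on an aromatic carbon, with vinyl in place of 4-fluoro-2,5-dimethylphenyl on an aromatic carbon. Within the data shown here, the one measured step bearing on this is a step that the two limits leave unreadable from compound 1 to compound 2, and the record holds only (the limit of > 20000 nM in this assay, at which 2 of the 2 values shown sit). No size or direction can be drawn from compound 2 at that limit, so no change beyond the scatter is expected in this assay. The expected change is a number no higher from compound 2 to compound 3 (the limit leaves the size open). For compound 3 the estimate is 20000 nM, with an expected range of 6000 nM to 40000 nM.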

Compound 3, half-maximal inhibitory concentration: 9700 nM
For compound 3 the middle estimate is 2.1-fold (0.31 log units) above the measured one, within the range that was stated.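

In this assay, this aromatic carbon of the shared core now yields a readable number: vinyl brings an at least 2.0-fold lower number from compound 2 to compound 3 (0.31 log units; beyond the scatter), and the same group brings an at least 2.0-fold lower number from compound 1 to compound 3 (0.31 log units; beyond the scatter). The step between compound 1 and compound 2 cannot be read, and only the two compounds with a six-membered aromatic ring at this carbon sit at the limit: the limit of > 20000 nM in this assay, at which 2 of the 3 values shown sit.

On these data alone, both readable steps are bounded on one side only, so their true size stays open. As far as these compounds go, whether the double bond of vinyl or the absence of a ring matters is also open, as is how ethyl, a longer chain or an amine at this carbon would read.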